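Trimming the Sulfur Benzyl Group of a Spleen Activator

The compounds below may be only part of what the source reports. "The series", "measured", "known", "first", "only" and "open" are said of these compounds alone.

Going by the values given here, compound 1 `Nc1nc(SCc2ccccc2)nc2c1nc(O)n2Cc1ccccc1` gives 0.1 uM in a functional assay (spleen, spleen) for activation, with Mus musculus as the target (a higher number here means that more compound is needed for the effect, a lower number that less compound is needed), the lowest of the three numbers known so far. Compound 2 `COc1cccc(Cn2c(O)nc3c(N)ncnc32)c1` gives 10 uM in this assay, and compound 3 `Cc1ccc(Cn2c(O)nc3c(N)ncnc32)cc1` gives 10 uM; both stand far above compound 1, and nothing nearer to it has been measured. Compound 4 `Nc1nc(S)nc2c1nc(O)n2Cc1ccccc1` awaits measurement. It differs from compound 1 in one place: hydrogen in place of benzyl on a sulfur. Among the compounds with values here, no measured pair covers this change, so the direction can only be judged from the three numbers themselves. Compound 4 is expected to move away from compound 1 toward the weaker pair, a step of a 30-fold higher number from compound 1 to compound 4 (1.48 log units; beyond the scatter) that is expected to lie beyond the scatter. Compound 4 is estimated at 3 uM, with a range from 0.3 uM to 30 uM.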

Compound 4, minimum effective concentration: 10 uM
Estimate against measurement, compound 4: 3.3-fold (0.52 log units) below; measured number inside the range.
By their numbers in this assay, from the lowest: compound 1; then compounds 2, 3 and 4 (each within the scatter of the next).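

Going by these compounds alone, removing the benzyl from the sulfur while leaving the rest of compound 1 unchanged gives a 100-fold higher number from compound 1 to compound 4 (2.00 log units; beyond the scatter) in this assay, the first step to isolate this position. The step is large and beyond the scatter, so the low number of compound 1 depends on the benzyl group on this sulfur. Nothing given here explains why the loss is so large.

As far as these compounds go, it remains open whether a methyl or a longer alkyl chain on the sulfur would keep the low number of compound 1. From the compounds shown here alone, it is also open whether a substituted benzyl or an amine in place of the benzylsulfanyl group would do so.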